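This account rests on a few compounds, and the source may have more. Where it says the series, first, only, none or still open, it means among the compounds named here.

Compound 1 `CN(C)C(=O)/C=C1\CCc2ccc(F)cc21`: > 100 mg/kg
Compound 2 `CCN(C)C(=O)/C=C1\CCc2c(F)cc(F)cc21`: 56 mg/kg

In a functional assay on the whole organism with Mus musculus as the target (a lower number here means that less compound is needed, a higher number that more compound is needed for the effect), compound 1 gives > 100 mg/kg, which is a limit of the assay and not a number. On these data alone, this leaves compound 1 at the limit of > 100 mg/kg in this assay, at which 1 of the 2 values shown sits, so its true position is unknown. Compound 2 differs from compound 1 in more than one place. Compound 2 gives a measured 56 mg/kg. Compound 3 `O=C(/C=C1\CCc2ccc(F)cc21)NC1CCC1` keeps the core of compound 1 and carries cyclobutylamino in place of dimethylamino on a carbonyl carbon. Among the compounds with values here, no measured pair isolates this change, so the expectation in this assay is only a modest step towards a lower dose, and the result could again be a limit. The estimate means an at least 1.6-fold lower number from compound 1 to compound 3 (0.22 log units; that floor lies within the scatter), an expected step of uncertain size. For compound 3 the expected value is 60 mg/kg, with an estimated range from 25 mg/kg to 150 mg/kg.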

Compound 3, dose for half-maximal effect: > 100 mg/kg
Compound 3 was reported as a limit; the forecaster's own chance of this, stated with the estimate: 25%; at least 1.6-fold (0.22 log units) between middle value and limit.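

Compound 1 and compound 3 both stand at a limit of the assay, so no step can be read between them: the limit of > 100 mg/kg in this assay, at which 2 of the 3 values shown sit.

The compounds shown leave open whether cyclobutylamino in place of dimethylamino on a carbonyl carbon changes the dose needed in this assay at all.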